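The source may report more compounds than this note shows. Statements on the series, on what has been measured and on what is new or still open speak of the compounds shown alone.

Working notes on the series, step from compound 1 to compound 4.

Compound 1 `Cc1ccc(Cn2cc(CNC(=O)c3cnc(Nc4ccc(C#N)cc4)cc3Oc3c(C)cc(C)cc3C)nn2)cc1` is the anchor. In an ADME assay on MT4 cells (Homo sapiens) for cytotoxicity, read by MTT assay, with a stated time of 5 days (on this read-out higher numbers stand for lower toxicity in this test and lower numbers for higher toxicity in this test), compound 1 gives 165000 nM, the highest of the two numbers in the set. Compound 2 `Cc1cc(C)c(Oc2cc(Nc3ccc(C#N)cc3)ncc2C(=O)NCc2cn(CC(N)=O)nn2)c(C)c1` gives 24000 nM in this assay. Compound 3 `Cc1cc(C)c(Oc2cc(Nc3ccc(C#N)cc3)ncc2C(=O)NCc2cn(Cc3ccc(F)cc3)nn2)c(C)c1` gives only a limit of this assay, >= 153000 nM, namely (the limit of >= 153000 nM in this assay, at which 1 of the 3 values shown sits). Compound 4 `Cc1cc(C)c(Oc2cc(Nc3ccc(C#N)cc3)ncc2C(=O)NCc2cn(CCC#N)nn2)c(C)c1` is not yet measured; against compound 1 the change is cyanomethyl in place of 4-methylphenyl on a saturated chain carbon bound to an aromatic nitrogen.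

Within the data shown here, two measured steps bear on this. Exchanging the same 4-methylphenyl for carbamoyl at the same place gave a 6.9-fold lower number from compound 1 to compound 2 (0.84 log units; beyond the scatter), and the reverse direction, 4-fluorophenyl in place of carbamoyl, gave an at least 6.3-fold higher number from compound 2 to compound 3 (0.80 log units; beyond the scatter). The direct comparison of the two ring-bearing groups is a step that the limit leaves unreadable from compound 1 to compound 3. Cyanomethyl, like carbamoyl, enters with no ring and one hydrogen-bond acceptor at the saturated chain carbon bound to an aromatic nitrogen, so a lower number, modest in size, is expected for compound 4, with the width kept broad since only one such pair exists. The expected step is a 3.3-fold lower number from compound 1 to compound 4 (0.52 log units; beyond the scatter). Compound 4 is therefore estimated at 50000 nM, between 18000 nM and 160000 nM.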

Compound 4, half-maximal cytotoxic concentration: 40200 nM
Beside the measured number, compound 4's estimate is 1.2-fold (0.09 log units) above it; measured number inside the range.
By their numbers in this assay, from the lowest: compounds 2 and 4 (each within the scatter of the next); then compound 1.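

In this assay, cyanomethyl in place of carbamoyl gives a 1.7-fold higher number from compound 2 to compound 4 (0.22 log units; within the scatter), so the two groups without a ring are not separated at this place. Cyanomethyl in place of the ring-bearing groups gives a 4.1-fold lower number from compound 1 to compound 4 (0.61 log units; beyond the scatter) and an at least 3.8-fold lower number from compound 3 to compound 4 (0.58 log units; beyond the scatter), so across these four compounds the ring-bearing groups on the saturated chain carbon bound to an aromatic nitrogen give the higher numbers, with no compound against this pattern. The value of compound 3 is a limit: the limit of >= 153000 nM in this assay, at which 1 of the 4 values shown sits.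

In these compounds the presence of an aromatic ring and the size of the group change together, so the two cannot be told apart. On these data alone, how cyclohexylmethyl, a longer alkyl chain with no ring, or a carboxylic acid on the chain would read at this place stays open.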